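This account rests on a few compounds, and the source may have more. Where it says the series, first, only, none or still open, it means among the compounds named here.

Measured compounds:
- compound 1, `CSc1nc(-c2ccc(F)cc2)c(-c2ccnc(NCCC(C)C)c2)[nH]1`: "not determined" (no result reported)
- compound 2, `CSc1nc(-c2cccc(C(F)(F)F)c2)c(-c2ccnc(NC(C)C(C)C)c2)[nH]1`: 1360 nM

Compound 1 stands nowhere on the numbers: in a functional assay on blood (Homo sapiens) for inhibition (on this read-out higher numbers stand for weaker inhibition and lower numbers for stronger inhibition), compound 1 gives "not determined" (no result reported), so no strength of inhibition is known for it. Among the compounds with values here, the only number in this set belongs to compound 2, which in this assay gives 1360 nM; compound 2 differs from compound 1 in more than one place, so its value cannot be read as a step from compound 1.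

Compound 3, `CSc1nc(-c2ccc(F)cc2)c(-c2ccnc(NC(C)CCc3ccccc3)c2)[nH]1`, has not been measured in this assay. It arises from compound 1 by one change: 1-methyl-3-phenylpropyl in place of isopentyl on a nitrogen on an aromatic ring.

Within the data shown here, with no number for compound 1, no step from compound 1 to compound 3 can be given. Among the measured compounds shown here, the one anchor is compound 2, whose 1360 nM in this assay shows what this shared core can reach. Compound 3 is expected to fall in a similar region, with the direction of any difference from compound 1 unknown and the spread wide. The estimated value for compound 3 in this assay is 1000 nM, within a range of 150 nM to 6000 nM.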

Compound 3, half-maximal inhibitory concentration: 2370 nM
Estimate against measurement, compound 3: 2.4-fold (0.37 log units) below; low and high end bracket the measured number.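

In this assay, within the data shown here, compound 3 gives 2370 nM, but compound 1 has no number to compare it with, so no step between compound 1 and compound 3 can be read. The compounds shown leave open how replacing isopentyl with 1-methyl-3-phenylpropyl changes inhibition. No evidence shown here bears on this result.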